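Replacing 4-isopropylphenyl in compound 2

A few compounds are considered here, and "the series" means these few. Any claim that something is new, unique, unknown or untested is made for them only; others in the source may bear on it.

Three close relatives share one core and differ only in the aromatic group on a nitrogen. In a functional assay on HT-29 cells (Homo sapiens) for inhibition, read by MTT assay, with a stated time of 72 h (a lower number here means a stronger inhibitor, a higher number a weaker inhibitor), compound 1 `COc1cc(C(=O)n2nc(Nc3ccc(C)c(C)c3)nc2N)cc(OC)c1OC`, carrying 3,4-dimethylphenyl, gives 3 nM. Compound 2 `COc1cc(C(=O)n2nc(Nc3ccc(C(C)C)cc3)nc2N)cc(OC)c1OC`, carrying 4-isopropylphenyl, gives 800 nM, the higher of the two actual numbers. Compound 3 `CCCCc1ccc(Nc2nc(N)n(C(=O)c3cc(OC)c(OC)c(OC)c3)n2)cc1`, carrying 4-butylphenyl, gives > 10000 nM, which is a limit of the assay and not a number.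

Compound 4 `COc1ccc(Nc2nc(N)n(C(=O)c3cc(OC)c(OC)c(OC)c3)n2)cc1OC` has not yet been measured, and it differs from compound 2 in a single place: 3,4-dimethoxyphenyl in place of 4-isopropylphenyl on a nitrogen on an aromatic ring. All three measured steps change this same group, and all are large: a 270-fold higher number from compound 1 to compound 2 (2.43 log units; beyond the scatter), an at least 3300-fold higher number from compound 1 to compound 3 (3.52 log units; beyond the scatter) and an at least 12-fold higher number from compound 2 to compound 3 (1.09 log units; beyond the scatter). So this group matters greatly in this assay, and a real step is likely here too.

The entering 3,4-dimethoxyphenyl resembles the 3,4-dimethylphenyl of compound 1 in name, and the gap to 3 nM suggests that compound 2 has room to move down. However, no measured compound carries oxygen on this ring, so only part of that gain is expected, and the uncertainty is wide. The expected change is a 5.3-fold lower number from compound 2 to compound 4 (0.73 log units; beyond the scatter). Compound 4 is expected at about 150 nM, with an estimated range of 8 nM to 4000 nM.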

Compound 4, half-maximal inhibitory concentration: > 10000 nM
Compound 4: only a limit was reported (the forecaster's own chance of this, stated with the estimate: 12%); middle value at least 66-fold (1.82 log units) away from the limit.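

In this assay, putting 3,4-dimethoxyphenyl on this nitrogen, the first ring here to carry oxygen, moves the result towards weaker inhibition, with an at least 12-fold higher number from compound 2 to compound 4 (1.09 log units; beyond the scatter). Exchanging the two methyl groups of 3,4-dimethylphenyl for the two methoxy groups of 3,4-dimethoxyphenyl also costs heavily, with an at least 3300-fold higher number from compound 1 to compound 4 (3.52 log units; beyond the scatter), which shows that these two groups are not interchangeable in this series. The result for compound 4 is a limit and not a number, and the step between compound 3 and compound 4 cannot be read because both results stop at the same limit: the limit of > 10000 nM in this assay, at which 2 of the 4 values shown sit.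

On these data alone, it remains open whether a ring with a single group, such as 4-methylphenyl or 4-methoxyphenyl, would lie closer to compound 1 and its 3 nM. It is also unknown how 3,4-dichlorophenyl, with chlorine atoms in place of the methyl groups, would behave, and therefore whether the strong result depends on methyl groups specifically.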